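Bromo in place of methoxy on compound 3

The compounds below may be only part of what the source reports. "The series", "measured", "known", "first", "only" and "open" are said of these compounds alone.

Measured in a functional assay on MCF7 cells (Homo sapiens) for inhibition, read by MTT assay, with a stated time of 72 h; on this read-out lower numbers stand for stronger inhibition and higher numbers for weaker inhibition:
- compound 1 `COc1ccc(-c2nnc(SCCCN3CCN(c4nc5ccccc5o4)CC3)o2)cc1`: 52800 nM
- compound 2 `Oc1ccc(-c2nnc(SCCCN3CCN(c4nc5ccccc5o4)CC3)o2)cc1`: 260000 nM
- compound 3 `COc1ccc(-c2nnc(SCCCN3CCN(c4nc5ccccc5s4)CC3)o2)cc1`: 171000 nM

Among these three numbers, compound 3 lies within the scatter of compound 2, and both are clearly higher than compound 1. The unmeasured compound 4 `Brc1ccc(-c2nnc(SCCCN3CCN(c4nc5ccccc5s4)CC3)o2)cc1` differs from compound 3 by bromo in place of methoxy on an aromatic carbon. The change is bromo in place of methoxy on an aromatic carbon, para to a large group.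

Among the compounds with values here, two measured steps bear on this, both modest. The closer one is a 4.9-fold higher number from compound 1 to compound 2 (0.69 log units; beyond the scatter), with hydrogen in place of methyl on an oxygen on an aromatic ring. It alters the same methoxy group, but it does not introduce bromo, so it is only a weak guide. The other is a 3.2-fold higher number from compound 1 to compound 3 (0.51 log units; beyond the scatter), with 1,3-benzothiazol-2-yl in place of 1,3-benzoxazol-2-yl on an amine nitrogen in a ring. It lies at a different place and says nothing directly about the methoxy group.

Within the data shown here, no bromo compound has been measured, so no firm direction can be given, and no step beyond the scatter is expected in this assay. The estimated change is a 1.2-fold lower number from compound 3 to compound 4 (0.09 log units; within the scatter). For compound 4 the estimated value is 140000 nM, with an expected range from 45000 nM to 400000 nM.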

Compound 4, half-maximal inhibitory concentration: 96300 nM
Estimate against measurement, compound 4: 1.5-fold (0.16 log units) above; measured number inside the range.
By their numbers in this assay, from the lowest: compounds 1, 4, 3 and 2 (each within the scatter of the next, the first and the last beyond it).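

At the aromatic carbon para to a large group, the change from 4-methoxyphenyl to 4-bromophenyl gives a 1.8-fold lower number from compound 3 to compound 4 (0.25 log units; within the scatter) in this assay, so on the 1,3-benzothiazol-2-yl background this methoxy group can give way to bromo without a step beyond the scatter. Within the data shown here, the only earlier step at this group, a 4.9-fold higher number from compound 1 to compound 2 (0.69 log units; beyond the scatter), was beyond the scatter, but it was read on the 1,3-benzoxazol-2-yl background and involved a different replacement, so the two steps show neither a shared trend nor a general tolerance at this position. No measured evidence is available to explain the result for compound 4, and the step itself gives no cause.

Going by these compounds, it remains open whether bromo in place of methoxy on compound 1, which gives 52800 nM, would also stay within the scatter, since the effect of this change may not carry over to the 1,3-benzoxazol-2-yl background. The compounds shown also leave open how chloro, an amine or a carboxylic acid at the same aromatic carbon would read in this assay.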